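A few compounds are considered here, and "the series" means these few. Any claim that something is new, unique, unknown or untested is made for them only; others in the source may bear on it.

Three compounds of this series carry measured numbers. Compound 1 `Cc1c(C)c2ccc(OCC3CCCN(Cc4ccc(CO)cc4)C3)cc2oc1=O` gives, in an assay for inhibition of Amine oxidase [flavin-containing] A (Homo sapiens), read by fluorescence, using microsomes, with a stated time of 30 min (on this read-out higher numbers stand for weaker inhibition and lower numbers for stronger inhibition), 1100 nM. Compound 2 `Cc1c(C)c2ccc(OCC3CCCN(Cc4cccc(CO)c4)C3)cc2oc1=O` gives in this assay 2200 nM. Compound 3 `Cc1c(C)c2ccc(OCC3CCN(Cc4ccc(CO)cc4)CC3)cc2oc1=O` gives in this assay 1400 nM. On these numbers compound 3 sits between the other two, but its distance to compound 1 and its distance to compound 2 both lie within the usual scatter, so no ordering among the three can be read from them.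

Compound 4 `Cc1c(C)c2ccc(OCC3CCN(Cc4cccc(CO)c4)CC3)cc2oc1=O` is not yet measured. From compound 3 it differs only by 3-(hydroxymethyl)phenyl in place of 4-(hydroxymethyl)phenyl on a saturated chain carbon bound to an amine nitrogen in a ring; the two share every atom and are joined differently.

Among the measured compounds shown here, one measured step bears on this change directly: the same swap on the other saturated ring gave a 2.0-fold higher number from compound 1 to compound 2 (0.30 log units; within the scatter), a step that does not clear the scatter. With a single precedent and no contrary case, the expectation for compound 4 is a step of similar size or none beyond the scatter in this assay, with a weak lean toward a higher number because of a 2.0-fold higher number from compound 1 to compound 2 (0.30 log units; within the scatter).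

Compound 4 is therefore estimated at 2500 nM in this assay, with a range of 1200 nM to 5500 nM, which would mean a 1.8-fold higher number from compound 3 to compound 4 (0.25 log units; within the scatter).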

Compound 4, half-maximal inhibitory concentration: 1900 nM
Estimate against measurement, compound 4: 1.3-fold (0.12 log units) above; low and high end bracket the measured number.
By their numbers in this assay, from the lowest: compounds 1, 3, 4 and 2 (each within the scatter of the next).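

The exchange of 4-(hydroxymethyl)phenyl for 3-(hydroxymethyl)phenyl on a saturated chain carbon bound to an amine nitrogen in a ring now has a second reading on a different core: in this assay it gives a 1.4-fold higher number from compound 3 to compound 4 (0.13 log units; within the scatter) and thus stays inside the scatter, as the first reading did. The result turns a single precedent into a small matched pair, and the two readings agree within their own scatter: the same change on two cores in this assay, a 2.0-fold higher number (0.30 log units; within the scatter) from compound 1 to compound 2 and a 1.4-fold higher number (0.13 log units; within the scatter) from compound 3 to compound 4, 1.5-fold (0.17 log units) apart, within the scatter of two such steps. On the two cores shown, therefore, the choice between 4-(hydroxymethyl)benzyl and 3-(hydroxymethyl)benzyl does not separate the compounds in this read-out, and neither reading goes against that.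

Still open, going by these compounds, is whether this place responds at all to a larger change, such as a carboxylic acid or an amine in place of the hydroxymethyl, or a longer chain carrying the hydroxyl, any of which might give a step that clears the scatter. On these data alone, all four numbers also come from a single assay, so how the hydroxymethyl exchange reads on any other enzyme preparation or target remains unknown.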